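Replacing Ethylamino with Ethyl on the Shared Core

The source may report more compounds than this note shows. Statements on the series, on what has been measured and on what is new or still open speak of the compounds shown alone.

Of the compounds shown here, three built on one shared core have been measured in a functional assay (spleen, spleen) for activation, with Mus musculus as the target; a lower number here means that less compound is needed, a higher number that more compound is needed for the effect. Compound 1 `Nc1nc(O)nc2c1nc(O)n2Cc1ccccc1` carries a hydroxy group on the aromatic carbon in question and gives 0.1 uM. Compound 2 `CCCSc1nc(N)c2nc(O)n(Cc3ccccc3)c2n1` carries propylsulfanyl at that carbon and gives 0.01 uM, which is a 10-fold lower number from compound 1 to compound 2 (1.00 log units; beyond the scatter). Compound 3 `CCNc1nc(N)c2nc(O)n(Cc3ccccc3)c2n1` carries ethylamino there and gives 1 uM, the highest number of the three: a 10-fold higher number from compound 1 to compound 3 (1.00 log units; beyond the scatter), and a 100-fold higher number from compound 2 to compound 3 (2.00 log units; beyond the scatter).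

Compound 4 `CCc1nc(N)c2nc(O)n(Cc3ccccc3)c2n1` has not yet been measured. It differs from compound 3 in one place: ethyl in place of ethylamino on an aromatic carbon. Among the measured compounds shown here, no measured step exchanges ethylamino for ethyl, so no step bears on this change directly. What the data do show is that the other two groups at this carbon both gave lower numbers than the ethylamino of compound 3, as seen in a 10-fold higher number from compound 1 to compound 3 (1.00 log units; beyond the scatter) and a 100-fold higher number from compound 2 to compound 3 (2.00 log units; beyond the scatter). A modest lowering is therefore expected, a 3.3-fold lower number from compound 3 to compound 4 (0.52 log units; beyond the scatter). Compound 4 is estimated at 0.3 uM, with a likely range from 0.03 uM to 3 uM.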

Compound 4, minimum effective concentration: 1 uM
Beside the measured number, compound 4's estimate is 3.3-fold (0.52 log units) below it; the measured number falls inside the stated range.
By their numbers in this assay, from the lowest: compound 2; then compound 1; then compounds 3 and 4 (each within the scatter of the next).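

In this assay, ethyl in place of ethylamino gives (no change at the digits printed from compound 3 to compound 4 (within the scatter)): the nitrogen, along with the hydrogen-bond donor and acceptor counted on ethylamino, leaves with no change in the number at the digits printed. Ethyl also stands as far from the other two groups at this carbon as ethylamino does (a 100-fold higher number from compound 2 to compound 4 (2.00 log units; beyond the scatter); a 10-fold higher number from compound 1 to compound 4 (1.00 log units; beyond the scatter)), so among these four compounds, both propylsulfanyl and hydroxy give lower numbers than ethyl and ethylamino. No evidence is available to explain this result.

The compounds shown leave open whether the low number of compound 2 goes with its sulfur atom or with its longer chain. A propyl group and an ethylsulfanyl group at this carbon would separate those two features.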